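This account rests on a few compounds, and the source may have more. Where it says the series, first, only, none or still open, it means among the compounds named here.

Working notes on the series.

Three compounds carry numbers in an ADME assay on microsomes from liver (Homo sapiens) for metabolic stability, tested at 2.5 uM; on this read-out higher numbers stand for fast clearance and lower numbers for slow clearance. Compound 1 `COc1ccc(-c2c(S(=O)(=O)c3ccc(F)c(F)c3)cnc3cc(F)ccc23)cc1` gives 1.1 mL/min; compound 2 `COc1ccc(-c2c(S(=O)(=O)c3cc(F)cc(F)c3)cnc3c(F)cccc23)cc1` gives 2.59 mL/min; compound 3 `O=S(=O)(c1ccc(F)c(F)c1)c1cnc2cc(F)ccc2c1-c1ccc(Cl)cc1` gives 0.01 mL/min, the lowest of the three, with compound 1 the nearest of the others and compound 2 the furthest. Among the compounds with values here, the single step measured between compounds that differ in one place runs from compound 1 to compound 3 and reads a 110-fold lower number from compound 1 to compound 3 (2.04 log units; beyond the scatter), a large drop tied to chloro in place of methoxy on an aromatic carbon. Compounds 1 and 2 differ in more than one place, so their values are only compared, not read as a step.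

Compound 4 `O=S(=O)(c1ccc(F)c(Cl)c1)c1cnc2cc(F)ccc2c1-c1ccc(Cl)cc1` is the next member. Its change from compound 3 is chloro in place of fluoro on an aromatic carbon, a halogen exchange on the sulfonyl-bearing ring. Within the data shown here, no measured step touches that ring, and the one measured step concerns a different group on a different ring, so it offers no direct guide. With compound 3 already at the low end of what this assay reports, the expected step of a 1.2-fold higher number from compound 3 to compound 4 (0.08 log units; within the scatter) is none beyond the scatter. Compound 4 is therefore estimated at 0.012 mL/min, within 0.004 mL/min to 0.04 mL/min.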

Compound 4, intrinsic clearance in a liver preparation (reported as CLH), per the amount of preparation that the assay uses: 0.39 mL/min
For compound 4 the middle estimate is 33-fold (1.51 log units) below the measured one; measured number outside the range, above it.
By their numbers in this assay, from the lowest: compound 3; then compound 4; then compound 1; then compound 2.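

In this assay the ring carrying the sulfonyl group proves sensitive to a single halogen: the change from 3,4-difluorophenyl to 3-chloro-4-fluorophenyl, ortho to a fluoro group, gives a 39-fold higher number from compound 3 to compound 4 (1.59 log units; beyond the scatter) as its step. Within the data shown here, this is the first measured step on that ring, and it is printed as large, as is the only earlier step (on the other aryl ring), which reads a 110-fold lower number from compound 1 to compound 3 (2.04 log units; beyond the scatter) and runs towards lower numbers. The compounds shown hold no measurement that bears on what lies behind this rise.

Whether the rise belongs to chloro itself remains open, since no other group, such as methyl, nitrile or an amine, is shown at this place. Also open, as far as these compounds go, is whether the same exchange gives a similar step when methoxy replaces the chloro on the other aryl ring.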